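Swapping Bromine for Fluorine on Two Different Cores

The source may hold more compounds than are shown below. What is called first, only, known or untested is meant among the compounds shown, and "the series" means these compounds.

Measured so far:
compound 1, `O=C(CSC(=S)N[C@H]1CCOC1=O)Nc1ccc(Br)cc1`, 66500 nM;
compound 2, `O=C(CSC(=S)N[C@H]1CCOC1=O)Nc1ccc(F)cc1`, 5830 nM;
compound 3, `O=C(CCl)Nc1ccc(C(=O)/C=C/c2ccc(Br)cc2)cc1`, 4640 nM.

All three values come from a functional assay on MCF7 cells (Homo sapiens) for cytotoxicity, read by MTT assay, with a stated time of 72 h; on this read-out higher numbers stand for weaker inhibition and lower numbers for stronger inhibition. Compound 1 and compound 2 share one core; compound 3 has a different core, and the difference between the two cores is not broken down here. Compound 1 to compound 2 is a single change, (fluoro in place of bromo on an aromatic carbon), and it gave an 11-fold lower number from compound 1 to compound 2 (1.06 log units; beyond the scatter). Compound 3 stands lowest of the three numbers, close to compound 2 and far from compound 1.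

Compound 4, `O=C(CCl)Nc1ccc(C(=O)/C=C/c2ccc(F)cc2)cc1`, is still to be measured in this assay. It differs from compound 3 by fluoro in place of bromo on an aromatic carbon, the same change, in the same surroundings, as from compound 1 to compound 2; among the compounds shown the change occurs twice. Among the measured compounds shown here, a lowering is expected for compound 4 because the earlier step of an 11-fold lower number from compound 1 to compound 2 (1.06 log units; beyond the scatter) was large, but since it was seen on only one other core, a more moderate step a 2.3-fold lower number from compound 3 to compound 4 (0.37 log units; beyond the scatter) is estimated. Compound 4 is therefore expected to give about 2000 nM, plausibly between 500 nM and 6000 nM.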

Compound 4, half-maximal inhibitory concentration: 5470 nM
Estimate against measurement, compound 4: 2.7-fold (0.44 log units) below, within the range that was stated.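

In this assay, putting fluoro in place of bromo on the second core gave a 1.2-fold higher number from compound 3 to compound 4 (0.07 log units; within the scatter), so on this core the swap left no readable change. Set beside the first core, the same swap did not carry over in size: the same change on two cores in this assay, an 11-fold lower number (1.06 log units; beyond the scatter) from compound 1 to compound 2 and a 1.2-fold higher number (0.07 log units; within the scatter) from compound 3 to compound 4, 13-fold (1.13 log units) apart, beyond the scatter of two such steps. Among the compounds shown here, this shows that the large step on one core cannot be assumed for the other, but with only two pairs in one cell assay, it does not show why the cores part ways or which feature of them matters.

The compounds shown hold only bromo or fluoro at this place on the ring, so it remains open whether chloro or methoxy there would follow the large step of the first core or the flat one of the second. From the compounds shown here alone, it also remains open whether the two cores would again part ways with a group such as an amine in that same place.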